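The source may report more compounds than this note shows. Statements on the series, on what has been measured and on what is new or still open speak of the compounds shown alone.

In a functional assay on HCT-15 cells (Homo sapiens) for inhibition (a higher number here means a weaker inhibitor, a lower number a stronger inhibitor), compound 1 (`Oc1ccc(-c2cc(-c3ccccc3F)cc(-c3ccccc3O)n2)cc1`) gives > 50000 nM as its reading, which is a limit and not a number. Compound 2 (`Oc1ccc(-c2cc(-c3ccccc3F)cc(-c3cccc(O)c3)n2)cc1`) gives 5630 nM and compound 3 (`Oc1ccc(-c2cc(-c3ccccc3F)cc(-c3ccc(O)cc3)n2)cc1`) gives 8180 nM as measured numbers. For the measured compounds named here, the gap is a 1.5-fold higher number from compound 2 to compound 3 (0.16 log units; within the scatter) and leaves the two level, so compound 3 has no clear rank against its only numeric neighbour.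

Compound 4 (`Oc1ccc(-c2cc(-c3ccccc3C(F)(F)F)cc(-c3ccc(O)cc3)n2)cc1`) departs from compound 3 at one place: trifluoromethyl in place of fluoro on an aromatic carbon is the change, trifluoromethyl in place of fluoro on an aromatic carbon. The steps beyond the scatter, an at least 8.8-fold lower number from compound 1 to compound 2 (0.94 log units; beyond the scatter) and an at least 6.1-fold lower number from compound 1 to compound 3 (0.78 log units; beyond the scatter), both concern the hydroxyphenyl group and not this position. Going by the values given here, no measured step touches the fluoro group, so the series gives no size for this change. The working expectation in this assay is therefore no step beyond the scatter, with a wide margin in either direction, anchored on compound 3 at 8180 nM as the starting value. The estimated shift is a 1.2-fold lower number from compound 3 to compound 4 (0.07 log units; within the scatter) at the middle of the range. For compound 4 the expected value is 7000 nM, with an estimated range from 2500 nM to 20000 nM around it.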

Compound 4, half-maximal inhibitory concentration: > 50000 nM
Compound 4: a limit, no number; the forecaster's own chance of this, stated with the estimate: 10%; at least 7.1-fold (0.85 log units) between middle value and limit.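

In this assay, the place ortho to a large group now has a measured response: trifluoromethyl in place of fluoro gives an at least 6.1-fold higher number from compound 3 to compound 4 (0.78 log units; beyond the scatter). For the compounds shown here, this is the first step at this position, as the earlier steps concerned only the hydroxyphenyl group, and it shows that going from 2-fluorophenyl to 2-(trifluoromethyl)phenyl is not a neutral change on the core of compound 3. The reading of compound 4 is a limit and not a number, so the full size of the step stays unknown: the limit of > 50000 nM in this assay, at which 2 of the 4 values shown sit.

With only fluoro and trifluoromethyl at this position, the compounds shown cannot tell how far the outcome is specific to trifluoromethyl; chloro, methyl or methoxy here would help to settle that. Also open, from the compounds shown here alone, is whether the same change gives a similar step with the 3-hydroxyphenyl group of compound 2.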